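The source may hold more compounds than are shown below. What is called first, only, known or untested is meant among the compounds shown, and "the series" means these compounds.

Compound 1 `O=C1Nc2ccccc2/C1=N\c1nc(NC2CC2)c2ncn(C3C=CC(CO)C3)c2n1` gives 48000 nM in a functional assay on CCRF-CEM cells (Homo sapiens) for cytotoxicity; on this read-out higher numbers stand for lower toxicity in this test and lower numbers for higher toxicity in this test. Compound 2 `CN(C)c1ccc(/C=N/c2nc(NC3CC3)c3ncn(C4C=CC(CO)C4)c3n2)cc1` reaches only a limit of this assay, > 100000 nM. Compound 3 `COc1ccc(/C=N/c2nc(NC3CC3)c3ncn(C4C=CC(CO)C4)c3n2)c(O)c1` gives 100000 nM.

Of the two numbers shown, compound 1 holds the lower one, with compound 3 higher by a step beyond the scatter; compound 2 contributes only a limit. Compound 4 `Cc1ccc2c(c1)/C(=N\c1nc(NC3CC3)c3ncn(C4C=CC(CO)C4)c3n1)C(=O)N2` differs from compound 1 by methyl in place of hydrogen on an aromatic carbon. Among the compounds with values here, the single measured step, a number no higher from compound 2 to compound 3 (the limit leaves the size open), exchanges the aryl group on the imine carbon and runs from a limit to a number, so its size stays open (the limit of > 100000 nM in this assay, at which 1 of the 3 values shown sits); it does not involve the fused ring altered here. Within the data shown here, no measured step therefore bears on this change, and compound 4 is expected to remain within the scatter of compound 1, a 1.1-fold lower number from compound 1 to compound 4 (0.03 log units; within the scatter). Compound 4 is estimated at 45000 nM, between 15000 nM and 130000 nM.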

Compound 4, half-maximal cytotoxic concentration: 78000 nM
Beside the measured number, compound 4's estimate is 1.7-fold (0.24 log units) below it; low and high end bracket the measured number.
By their numbers in this assay, from the lowest: compounds 1, 4 and 3 (each within the scatter of the next, the first and the last beyond it).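

In this assay, methyl in place of hydrogen on an aromatic carbon gives a 1.6-fold higher number from compound 1 to compound 4 (0.21 log units; within the scatter) and so stays within the scatter. Within the data shown here, this is the only measured change on the fused ring system, and it shows that this carbon, meta to a fused ring and para to a fused ring, takes a methyl without a shift beyond the scatter. Nothing at hand explains this result. On these data alone, whether an amine or a carboxylic acid at this carbon would also stay within the scatter remains open. So does the outcome of a methyl on the other aromatic carbons of this ring.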